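Dimethylamide in place of primary amide on the cyclopropane

The source may report more compounds than this note shows. Statements on the series, on what has been measured and on what is new or still open speak of the compounds shown alone.

Measured compounds in a functional assay on CHO cells for agonist activity at Free fatty acid receptor 1 (Homo sapiens), read by a luciferase reporter; a higher number here means a larger maximal response, a lower number a smaller maximal response:
Compound 1 `Cc1nc(-c2ccc(C(F)(F)F)cc2)sc1CNc1ccc(CCCC(=O)O)cc1` gives 44%.
Compound 2 `Cc1nc(-c2ccc(C(F)(F)F)cc2)sc1CNc1ccc(CCC(N)=O)cc1` gives 88%.
Compound 3 `Cc1nc(-c2ccc(C(F)(F)F)cc2)sc1CNc1ccc([C@H]2C[C@@H]2C(N)=O)cc1` gives 80%.

Compound 3 stands second highest of the three numbers in this assay. Its nearest neighbour is compound 2, and the step of a number 8 percentage points lower from compound 2 to compound 3 (within the scatter) lies within the scatter, while a number 36 percentage points higher from compound 1 to compound 3 (beyond the scatter) is large. Compound 4 `Cc1nc(-c2ccc(C(F)(F)F)cc2)sc1CNc1ccc([C@H]2C[C@@H]2C(=O)N(C)C)cc1` carries the change (dimethylamino in place of amino on a carbonyl carbon).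

For the measured compounds named here, none of the measured steps touches the amide nitrogen: a number 44 percentage points higher from compound 1 to compound 2 (beyond the scatter) and a number 36 percentage points higher from compound 1 to compound 3 (beyond the scatter) exchange an acid for an amide, and a number 8 percentage points lower from compound 2 to compound 3 (within the scatter) alters the chain between the aromatic carbon and the carbamoyl group. Going by the values given here, no measured step therefore bears directly on this change, and the direction is open. For compound 4 a step of a number 10 percentage points lower from compound 3 to compound 4 (within the scatter) is expected. The estimate for compound 4 is 70%, between 45% and 95%.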

Compound 4, largest response reached (reported as percent of maximum), in percent of the reference or control that the assay uses: 49%
The estimate for compound 4 lay 21 percentage points above the measured number; the range from low to high includes it.
By their numbers in this assay, from the lowest: compounds 1 and 4 (each within the scatter of the next); then compounds 3 and 2 (each within the scatter of the next).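

In this assay, dimethylamino is no neutral replacement for amino on this carbonyl carbon, giving a number 31 percentage points lower from compound 3 to compound 4 (beyond the scatter) in a change confined to the amide nitrogen. The result extends to the other comparisons, with a number 39 percentage points lower from compound 2 to compound 4 (beyond the scatter) for the dimethylamide against the open-chain primary amide, and a number 5 percentage points higher from compound 1 to compound 4 (within the scatter) for the dimethylamide against the acid, so the gain seen with the primary amides is absent here. No measurement available here accounts for the drop.

Methylamino on the same carbonyl carbon could show whether one added methyl is enough to lower the response. Also open, from the compounds shown here alone, is how dimethylamino behaves on the 2-carbamoylethyl chain without the cyclopropane.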